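Aryl swap on the outer piperazine benzyl group

The source may report more compounds than this note shows. Statements on the series, on what has been measured and on what is new or still open speak of the compounds shown alone.

Compound 1 `CCN(CC)c1ccc2cc(C(=O)c3ccc(N4CCN(C(=O)CN5CCNCC5)CC4)cc3)oc2c1` gives 320 nM in a functional assay on A549 cells (Homo sapiens) for cytotoxicity, read by MTT assay, with a stated time of 48 h; on this read-out lower numbers stand for stronger inhibition and higher numbers for weaker inhibition. Compound 2 `CCN(CC)c1ccc2cc(C(=O)c3ccc(N4CCN(C(=O)CN5CCN(Cc6ccc(F)c(F)c6)CC5)CC4)cc3)oc2c1` gives 5440 nM in this assay, and stands highest of the two numbers shown. Compound 3 `CCN(CC)c1ccc2cc(C(=O)c3ccc(N4CCN(C(=O)CN5CCN(Cc6ccc(C#N)cc6)CC5)CC4)cc3)oc2c1` differs from it by 4-cyanophenyl in place of 3,4-difluorophenyl on a saturated chain carbon bound to an amine nitrogen in a ring. Among the compounds with values here, the only measured step, a 17-fold higher number from compound 1 to compound 2 (1.23 log units; beyond the scatter), concerns adding a benzyl group to a bare ring nitrogen and does not bear on exchanging one aryl for another. No step beyond the scatter is therefore expected in this assay; nothing here supports a direction. Compound 3 is estimated at 5000 nM, between 1500 nM and 16000 nM, an expected step of a 1.1-fold lower number from compound 2 to compound 3 (0.04 log units; within the scatter).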

Compound 3, half-maximal inhibitory concentration: 17400 nM
Beside the measured number, compound 3's estimate is 3.5-fold (0.54 log units) below it; the measured number lies above the stated range.
By their numbers in this assay, from the lowest: compound 1; then compound 2; then compound 3.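

The outer aryl group is not a silent position in this assay: 4-cyanophenyl in place of 3,4-difluorophenyl gives a 3.2-fold higher number from compound 2 to compound 3 (0.50 log units; beyond the scatter) on top of the rise already seen on benzylation. With this group, the total cost against the free ring nitrogen reaches a 54-fold higher number from compound 1 to compound 3 (1.74 log units; beyond the scatter) and both benzyl compounds stay well above compound 1. No measurement shown explains the difference between the two aryl groups.

The change removes both fluorines and adds a nitrile at once, leaving their separate contributions unresolved. Plain benzyl, 4-fluorobenzyl or acetyl on that nitrogen would show whether any group there can match the free amine.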